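This account rests on a few compounds, and the source may have more. Where it says the series, first, only, none or still open, it means among the compounds named here.

Of the compounds shown here, two have been measured. Compound 1, `CC(C)(C)Cc1c(-c2ccncc2)sc(N)c1C(=O)c1ccc(Cl)cc1`, shows 6% in an assay on CHO cells for displacement of a labelled ligand from adenosine receptor A3 (Homo sapiens), read by scintillation counting, tested at 10 uM; on this read-out higher numbers stand for more inhibition at the one concentration tested (going by the name of the read-out) and lower numbers for less inhibition. Compound 2, `Cc1cccc(-c2sc(N)c(C(=O)c3ccc(Cl)cc3)c2CC(C)(C)C)c1`, shows 1% in this assay. Going by the values given here, the single measured step, a number 5 percentage points lower from compound 1 to compound 2 (within the scatter), exchanges only the group on one aromatic carbon of the shared core. Compound 2 thus carries the lower of the two numbers, but its gap to compound 1 lies within the usual scatter, so the two compounds cannot be told apart on these data; both sit at the low end of the scale.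

Compound 3, `CC(C)(C)Cc1c(Br)sc(N)c1C(=O)c1ccc(Cl)cc1`, is the next compound. It differs from compound 2 at the same aromatic carbon: bromo in place of 3-methylphenyl on an aromatic carbon. Among the compounds with values here, no measured step exchanges a six-membered aromatic ring for a single bromine at this place, so the only guide is that the measured exchange of one aromatic ring for another left the number within the scatter, and that both measured numbers are low. For compound 3 the expected step is a number 4 percentage points higher from compound 2 to compound 3 (within the scatter), nothing beyond the scatter. Compound 3 is therefore estimated at 5% in this assay, with a range from 0% to 20%.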

Compound 3, a percentage reported as inhibition, at one concentration (the size of the read-out at that concentration, not a potency): 1%
The estimate for compound 3 lay 4 percentage points above the measured number; low and high end bracket the measured number.
By their numbers in this assay, from the lowest: compounds 2, 3 and 1 (each within the scatter of the next).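

Exchanging the 3-methylphenyl for a bromo at this carbon gives no change at the digits printed from compound 2 to compound 3 (within the scatter) in this assay, and exchanging the pyridin-4-yl for the same bromo gives a number 5 percentage points lower from compound 1 to compound 3 (within the scatter). The earlier step only swapped one six-membered aromatic ring for another, whereas these steps remove the ring altogether, and going from 7 heavy atoms to 1 heavy atom at this place still does not separate the compounds, with all three numbers remaining at the low end of the scale. No supporting information is available to explain why these numbers stay so close.

Because all three compounds sit so low, these data leave open whether any group at this carbon can raise the number beyond the scatter, for example an amine, a carboxylic acid or a longer chain such as n-hexyl. They also leave open how much the neopentyl, the amino group or the (4-chlorophenyl)carbonyl group contributes, since each of these stays the same in all three compounds.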